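Swapping dimethylamino for nitro on the pendant phenyl

This account rests on a few compounds, and the source may have more. Where it says the series, first, only, none or still open, it means among the compounds named here.

Compound 1 `CCOC(=O)c1c(-c2ccccc2OC)c(C#N)c(=O)n(/N=C(\C)c2ccc(NS(=O)(=O)c3ccc(Cl)cc3)cc2)c1N` gives 11400 nM in a functional assay on HepG2 cells (Homo sapiens) for cytotoxicity, read by sulforhodamine B assay, with a stated time of 48 h; a lower number here means a stronger inhibitor, a higher number a weaker inhibitor.
Compound 2 `CCOC(=O)c1c(-c2ccc(OC)cc2)c(C#N)c(=O)n(/N=C(\C)c2ccc(NS(=O)(=O)c3ccc(Cl)cc3)cc2)c1N` gives 61700 nM.
Compound 3 `CCOC(=O)c1c(-c2ccc(N(C)C)cc2)c(C#N)c(=O)n(/N=C(\C)c2ccc(NS(=O)(=O)c3ccc(Cl)cc3)cc2)c1N` gives 21000 nM.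

Compound 3 has the second highest number of the three: it sits within the scatter of compound 1, as a 1.8-fold higher number from compound 1 to compound 3 (0.27 log units; within the scatter) shows, while a 2.9-fold lower number from compound 2 to compound 3 (0.47 log units; beyond the scatter) is a modest step beyond the scatter. Compound 4 `CCOC(=O)c1c(-c2ccc([N+](=O)[O-])cc2)c(C#N)c(=O)n(/N=C(\C)c2ccc(NS(=O)(=O)c3ccc(Cl)cc3)cc2)c1N` differs from compound 3 by nitro in place of dimethylamino on an aromatic carbon. Only a 2.9-fold lower number from compound 2 to compound 3 (0.47 log units; beyond the scatter) touches the same place, and it moved the number modestly. Among the measured compounds shown here, no measured compound carries a nitro group, so its effect is unknown, and the direction of the step remains open. The account expects a step of a 1.4-fold higher number from compound 3 to compound 4 (0.15 log units; within the scatter) in this assay, not clearly beyond the scatter. Compound 4 is therefore estimated at 30000 nM, with a range from 9000 nM to 100000 nM.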

Compound 4, half-maximal inhibitory concentration: 41100 nM
The estimate for compound 4 lay 1.4-fold (0.14 log units) below the measured number, and the stated range covers the measured number.
By their numbers in this assay, from the lowest: compounds 1, 3, 4 and 2 (each within the scatter of the next, the first and the last beyond it).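

In this assay nitro on this aromatic carbon cannot be told apart from either group tested there before (a 2.0-fold higher number from compound 3 to compound 4 (0.29 log units; within the scatter); a 1.5-fold lower number from compound 2 to compound 4 (0.18 log units; within the scatter)), although dimethylamino and methoxy were separated by a modest step beyond the scatter. Only the change of 2-methoxyphenyl to 4-nitrophenyl goes beyond the scatter, and modestly (a 3.6-fold higher number from compound 1 to compound 4 (0.56 log units; beyond the scatter)). Nothing available explains these numbers.

On these data alone, how a primary amine or a carboxylic acid on this aromatic carbon would read remains open. So does whether any group here would take the number clearly beyond the span of these compounds.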